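The compounds below may be only part of what the source reports. "The series", "measured", "known", "first", "only" and "open" are said of these compounds alone.

The series shares the core of compound 1 `O=C(Nc1ccc(Cl)c(-c2nnc3c(Cl)cccn23)c1)c1cccc(Cl)c1`, an amide whose aryl group on the carbonyl carbon is varied. In a functional assay on U-251 cells (Homo sapiens) for antiproliferative activity, read by MTT assay, with a stated time of 72 h (on this read-out higher numbers stand for weaker inhibition and lower numbers for stronger inhibition), compound 1 gives 43100 nM. Compound 2 `O=C(Nc1ccc(Cl)c(-c2nnc3c(Cl)cccn23)c1)c1ccon1` carries 1,2-oxazol-3-yl on that carbonyl carbon. In this assay compound 2 returns only a limit, > 100000 nM. The step of an at least 2.3-fold higher number from compound 1 to compound 2 (0.36 log units; beyond the scatter) thus rests on that limit (the limit of > 100000 nM in this assay, at which 1 of the 2 values shown sits), and compound 2 stands at the weak end of what is shown. Compound 3 `CS(=O)(=O)c1cccc(C(=O)Nc2ccc(Cl)c(-c3nnc4c(Cl)cccn34)c2)c1` is the next change: 3-(methylsulfonyl)phenyl in place of 1,2-oxazol-3-yl on a carbonyl carbon. Going by the values given here, the one measured step that bears on it, an at least 2.3-fold higher number from compound 1 to compound 2 (0.36 log units; beyond the scatter), went in the opposite direction, from a six-membered aromatic ring of carbon only to the five-membered ring. Compound 3 returns to a six-membered aromatic ring of carbon only, so a drop back is expected, by an at least 1.6-fold lower number from compound 2 to compound 3 (0.22 log units; that floor lies within the scatter). Compound 3 is estimated at 60000 nM, with a range from 20000 nM to 200000 nM.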

Compound 3, half-maximal inhibitory concentration: > 100000 nM
Compound 3 gave a limit, no number; the forecaster's own chance of this, stated with the estimate: 35%; middle value at least 1.6-fold (0.22 log units) from the limit.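

On the carbonyl carbon, a six-membered aromatic ring of carbon only is not enough to keep a measurable value in this assay: compound 3, with 3-(methylsulfonyl)phenyl, gives only a limit, > 100000 nM. Methylsulfonyl in place of chloro on an aromatic carbon gives an at least 2.3-fold higher number from compound 1 to compound 3 (0.36 log units; beyond the scatter), so the loss seen with compound 2 is not confined to the five-membered ring. The step between compound 2 and compound 3 cannot be read, as both sit at the same limit: the limit of > 100000 nM in this assay, at which 2 of the 3 values shown sit.

Only compound 1 gives a number, so the shown compounds set no order among replacements for its chloro group. On these data alone, it stays open whether a methoxy group, an amine or a carboxylic acid on that aromatic carbon would keep, improve or lose the value of compound 1.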